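The source may report more compounds than this note shows. Statements on the series, on what has been measured and on what is new or still open speak of the compounds shown alone.

Measured so far in a functional assay on MDA-MB-231 cells (Homo sapiens) for antiproliferative activity, read by MTT assay, with a stated time of 48 h; a higher number here means a weaker inhibitor, a lower number a stronger inhibitor:
- compound 1 `CS(=O)(=O)c1ccc(Nc2ncc(F)c(Nc3nc4ccccc4s3)n2)cc1` gives 4980 nM
- compound 2 `Cc1cnc(Nc2ccc(C(C)C)cc2)nc1Nc1nc2ccccc2s1` reaches only the assay limit, > 50000 nM
- compound 3 `Cc1ccc2nc(Nc3nc(Nc4ccc(S(N)(=O)=O)cc4)ncc3C)sc2c1` gives 9080 nM

Of the three, compound 2 is the one that sits at the limit of this assay, (the limit of > 50000 nM in this assay, at which 1 of the 3 values shown sits), so for compound 2 there is no number, only a floor on the half-maximal inhibitory concentration. Compound 1 and compound 3 both return actual values, and the gap between them lies within the usual scatter.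

The next compound, compound 4 `Cc1cnc(Nc2ccc(F)cc2)nc1Nc1nc2ccccc2s1`, differs from compound 2 in one place: fluoro in place of isopropyl on an aromatic carbon of the phenyl ring, para to a large group. For the measured compounds named here, no measured pair in the set covers this change, so its size is not known from the data. Because compound 2 shows only a limit, > 50000 nM, any measurable value for compound 4 would already count as a gain; the expectation is a step in the direction of stronger inhibition, likely beyond the scatter, but with wide uncertainty and a real chance that compound 4 also stops at the limit.

Compound 4 is expected to give about 25000 nM in this assay, within 8000 nM to 80000 nM. The step this estimate would mean is expected to be an at least 2.0-fold lower number from compound 2 to compound 4 (0.30 log units; that floor lies within the scatter).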

Compound 4, half-maximal inhibitory concentration: > 50000 nM
Compound 4 was reported as a limit; the forecaster's own chance of this, stated with the estimate: 35%; middle value at least 2.0-fold (0.30 log units) away from the limit.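

For the compounds shown here, compound 2 and compound 4 each stand only as a limit in this assay so no step between them can be read. The compounds shown leave open what half-maximal inhibitory concentration either compound has, and whether fluoro in place of isopropyl on an aromatic carbon changes it.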